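Removing a Ring Hydroxyl on a Sulfone Core

The source may hold more compounds than are shown below. What is called first, only, known or untested is meant among the compounds shown, and "the series" means these compounds.

Compound 1 `CCC1(O)CS(=O)(=O)c2cc(C(=O)N=C(N)N)c(C)cc21` and compound 2 `CCC1CS(=O)(=O)c2cc(C(=O)N=C(N)N)c(C)cc21` share one core. In a functional assay for inhibition, with Homo sapiens as the target (on this read-out lower numbers stand for stronger inhibition and higher numbers for weaker inhibition), compound 1 gives 77 nM, and compound 2 gives 78 nM. The step of a 1.0-fold higher number from compound 1 to compound 2 (0.01 log units; within the scatter) accompanies the change (hydrogen in place of hydroxy on a saturated ring carbon). Compound 3 `N=C(N)NC(=O)c1ccc2c(c1)S(=O)(=O)CC2O` rests on another core; the difference between the two cores is not broken down here. In this assay compound 3 gives > 100000 nM, which is a limit of the assay and not a number, as noted in the limit of > 100000 nM in this assay, at which 1 of the 3 values shown sits. Compound 4 `N=C(N)NC(=O)c1ccc2c(c1)S(=O)(=O)CC2` is not yet measured; it differs from compound 3 by hydrogen in place of hydroxy on a saturated ring carbon, the same change that separates compound 1 from compound 2, at the same place. By analogy with the step of a 1.0-fold higher number from compound 1 to compound 2 (0.01 log units; within the scatter), the step that the limit leaves unreadable from compound 3 to compound 4 is expected to stay small. Compound 4 is therefore estimated at 150000 nM in this assay, from 30000 nM to 1000000 nM, most likely again only a limit.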

Compound 4, half-maximal inhibitory concentration: > 100000 nM
Compound 4 was reported as a limit (the forecaster's own chance of this, stated with the estimate: 80%); the middle value does not contradict the limit.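

Compound 3 and compound 4 are both reported only as limits, so no step between them can be read: the limit of > 100000 nM in this assay, at which 2 of the 4 values shown sit.

The compounds shown leave open whether hydrogen in place of hydroxy changes anything on the core of compound 3.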